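Acetyl in Place of Methoxy: What to Expect for Compound 4

A few compounds are considered here, and "the series" means these few. Any claim that something is new, unique, unknown or untested is made for them only; others in the source may bear on it.

Measured so far:
compound 1 `CC(C)c1ccccc1NC(=O)N[C@@H](C)c1ccccc1` with 93%
compound 2 `C[C@H](NC(=O)Nc1ccccc1C(C)(C)C)c1ccccc1` with 100%
compound 3 `COc1ccccc1NC(=O)N[C@@H](C)c1ccccc1` with 95%

Three compounds share one core and differ only in the group carried on an aromatic carbon. In an ADME assay on the whole organism with Oryza sativa as the target, tested at 10 uM (on this read-out lower numbers stand for a stronger effect and higher numbers for a weaker effect at the one concentration tested), compound 1 gives 93%, compound 2 gives 100% and compound 3 gives 95%. All three numbers sit close together: a number 2 percentage points higher from compound 1 to compound 3 (within the scatter), a number 5 percentage points lower from compound 2 to compound 3 (within the scatter), and likewise a number 7 percentage points higher from compound 1 to compound 2 (within the scatter). Compound 3 therefore stands within the scatter of both neighbours, and no ordering among the three can be read from these numbers.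

Compound 4 `CC(=O)c1ccccc1NC(=O)N[C@@H](C)c1ccccc1` is the next step from compound 3: acetyl in place of methoxy on an aromatic carbon. For the measured compounds named here, the steps that bear on this are the two that already exchanged the group at the same place, from compound 1 to compound 3 and from compound 2 to compound 3; both stayed within the scatter. A further exchange at that place is therefore expected to produce no step beyond the scatter, no change at the digits printed from compound 3 to compound 4 (within the scatter). The estimate for compound 4 in this assay is 95%, expected to fall between 84% and 100%.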

Compound 4, a percentage reported as activity, at one concentration (the size of the read-out at that concentration, not a potency): 96%
Compound 4: middle estimate off by 1 percentage points, on the low side; the range from low to high includes it.
By their numbers in this assay, from the lowest: compounds 1, 3, 4 and 2 (each within the scatter of the next).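

Acetyl adds a double bond outside aromatic rings at this place, on an aromatic carbon ortho to a large group, yet in this assay all three new steps remain small: a number 1 percentage points higher from compound 3 to compound 4 (within the scatter), a number 4 percentage points lower from compound 2 to compound 4 (within the scatter) and a number 3 percentage points higher from compound 1 to compound 4 (within the scatter). Isopropyl, tert-butyl, methoxy and acetyl at this place therefore give values that cannot be told apart, and this now includes a group with that double bond. No measurement at hand offers an explanation for this result.

On these data alone, it remains open whether an amine, a carboxylic acid or a longer chain at this place would also stay within the scatter, or whether any group here can shift this read-out beyond it. As far as these compounds go, the effect of changing another part of the shared core also remains open.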